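Replacing the Oxazole of Compound 3 with Pyrazine

A few compounds are considered here, and "the series" means these few. Any claim that something is new, unique, unknown or untested is made for them only; others in the source may bear on it.

Compound 3 `Cc1ccc(OCC(=O)N(Cc2cccs2)c2ccon2)cc1` holds the lowest number of the three compounds measured in an assay on HEK293 cells for agonist activity at transient receptor potential cation channel subfamily M member 8 (Homo sapiens), read by fluorescence and calcium flux, with a stated time of 15 min (a higher number here means that more compound is needed for the effect, a lower number that less compound is needed), giving 2 nM. Compound 2 `Cc1ccc(OCC(=O)N(Cc2cccs2)c2ccnn2C)cc1` gives 422 nM, and compound 1 `Cc1ccc(OCC(=O)N(Cc2cccs2)c2ncccn2)cc1` gives 3700 nM. Both steps to compound 3 are large and lie beyond the scatter: a 210-fold lower number from compound 2 to compound 3 (2.32 log units; beyond the scatter) and a 1900-fold lower number from compound 1 to compound 3 (3.27 log units; beyond the scatter). Compound 4 `Cc1ccc(OCC(=O)N(Cc2cccs2)c2cnccn2)cc1` differs from compound 3 by pyrazin-2-yl in place of 1,2-oxazol-3-yl on an amide-type nitrogen. The step that bears most is a 1900-fold lower number from compound 1 to compound 3 (3.27 log units; beyond the scatter). Compound 1 carries pyrimidin-2-yl on the same amide-type nitrogen, and the step of a 210-fold lower number from compound 2 to compound 3 (2.32 log units; beyond the scatter) points the same way. A large increase in the number is therefore expected. Compound 4 is estimated to give 1500 nM in this assay, between 200 nM and 8000 nM, which is an expected step of a 750-fold higher number from compound 3 to compound 4 (2.88 log units; beyond the scatter).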

Compound 4, half-maximal effective concentration: 1240 nM
Compound 4: the middle estimate sits 1.2-fold (0.08 log units) above what was measured; measured number inside the range.
By their numbers in this assay, from the lowest: compound 3; then compound 2; then compound 4; then compound 1.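

Pyrazin-2-yl on this amide-type nitrogen does not hold the low number of 1,2-oxazol-3-yl, with a 620-fold higher number from compound 3 to compound 4 (2.79 log units; beyond the scatter). It falls instead among the other two groups, with a 2.9-fold higher number from compound 2 to compound 4 (0.47 log units; beyond the scatter) and a 3.0-fold lower number from compound 1 to compound 4 (0.47 log units; beyond the scatter), so compound 3 alone stands apart. Pyrazin-2-yl and pyrimidin-2-yl, each a six-membered aromatic ring with 2 hetero atoms, still differ beyond the scatter, so the kind of ring alone does not fix the number.

Nothing at hand explains why 1,2-oxazol-3-yl stands apart. As far as these compounds go, whether 1,3-thiazol-2-yl or 1,2-oxazol-5-yl on the same nitrogen would keep the low number remains open.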